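Carbonyl Swap Between Two Inactive Neighbours

A few compounds are considered here, and "the series" means these few. Any claim that something is new, unique, unknown or untested is made for them only; others in the source may bear on it.

In an ADME assay on isolated protein for inhibition of high affinity cAMP-specific and IBMX-insensitive 3',5'-cyclic phosphodiesterase 8A (Homo sapiens) (a higher number here means a weaker inhibitor, a lower number a stronger inhibitor), compound 1 `CCn1ncc(-c2nc3c(O[C@H]4CCN(C(=O)C5CCOCC5)C4)ncnc3n2C)c1C` gives only a limit of the assay, > 50000 nM. Compound 2 `CCC(=O)N1CC[C@H](Nc2ncnc3c2nc(-c2cnn(CC)c2C)n3C)C1` likewise returns only a limit in this assay, > 20000 nM. Neither compound therefore stands at a number. Compound 1 sits at the limit of > 50000 nM in this assay, at which 1 of the 2 values shown sits. Compound 2 sits at the limit of > 20000 nM in this assay, at which 1 of the 2 values shown sits. Compound 3 `CCn1ncc(-c2nc3c(N[C@H]4CCN(C(=O)C5CCOCC5)C4)ncnc3n2C)c1C` is yet to be tested in this assay. It differs from compound 2 by oxan-4-yl in place of ethyl on a carbonyl carbon. Among the compounds with values here, no step between measured compounds is available to size this change, and compound 1, which carries the same oxan-4-yl carbonyl, also shows no number. The expected step that the limit leaves unreadable from compound 2 to compound 3 is none beyond the scatter. For compound 3 the estimated value in this assay is 40000 nM, within 15000 nM to 150000 nM, most likely reported again as only a limit.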

Compound 3, half-maximal inhibitory concentration: > 20000 nM
Compound 3 was reported as a limit; the forecaster's own chance of this, stated with the estimate: 85%; the middle value does not contradict the limit.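

In this assay compound 3 gives > 20000 nM as a limit of the assay, not a number. Within the data shown here, compound 2 likewise gives > 20000 nM as a limit, so no step between compound 2 and compound 3 can be read. The compounds shown leave open whether oxan-4-yl in place of ethyl on a carbonyl carbon changes inhibition at all, since none of them stands at a number.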